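Swapping Chloro for Methyl on a Urea-Bearing Analogue

The source may hold more compounds than are shown below. What is called first, only, known or untested is meant among the compounds shown, and "the series" means these compounds.

Compound 1 `CN1Cc2c(N)cccc2C(c2ccc(Cl)cc2)C1` and compound 2 `Cc1ccc(C2CN(C)Cc3c(N)cccc32)cc1` share one core and differ in a single group: methyl in place of chloro on an aromatic carbon. In a functional assay on the whole organism for inhibition, with Mus musculus as the target (on this read-out lower numbers stand for an effect already at smaller amounts and higher numbers for an effect only at larger amounts of compound), compound 1 gives 1.6 mg/kg, and compound 2 gives 1.6 mg/kg; the step of no change at the digits printed from compound 1 to compound 2 (within the scatter). Compound 3 `CCCCNC(=O)Nc1cccc2c1CN(C)CC2c1ccc(Cl)cc1` keeps the core of compound 1 but carries an added group: butylcarbamoyl in place of hydrogen on a nitrogen on an aromatic ring. In this assay compound 3 gives 44 mg/kg, and the step of a 28-fold higher number from compound 1 to compound 3 (1.44 log units; beyond the scatter), the highest number among the three measured compounds.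

Compound 4 `CCCCNC(=O)Nc1cccc2c1CN(C)CC2c1ccc(C)cc1` has not yet been measured. It stands to compound 3 exactly as compound 2 stands to compound 1: methyl in place of chloro on an aromatic carbon. The surroundings of the changed atom read the same in both pairs, so this is the same change, seen twice among the four compounds, and measured only once.

The expectation for compound 4 rests on that one measured instance. Because the step of no change at the digits printed from compound 1 to compound 2 (within the scatter) lies within the scatter, the step of no change at the digits printed from compound 3 to compound 4 (within the scatter) is expected to be equally small, leaving compound 4 close to compound 3 rather than to compound 1 or compound 2. Compound 4 is therefore expected to give about 44 mg/kg in this assay, with a likely range from 18 mg/kg to 110 mg/kg. A single prior instance is a thin basis, and compound 3 sits in a different range from compounds 1 and 2, so the estimate carries real uncertainty.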

Compound 4, dose for half-maximal effect: 40 mg/kg
Compound 4: the middle estimate sits 1.1-fold (0.04 log units) above what was measured, within the range that was stated.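

Exchanging chloro for methyl on the core that carries butylcarbamoyl gives a 1.1-fold lower number from compound 3 to compound 4 (0.04 log units; within the scatter), so in this assay the swap leaves the number as little moved on this core as on the core of compound 1: the same change on two cores in this assay, no change at the digits printed (within the scatter) from compound 1 to compound 2 and a 1.1-fold lower number (0.04 log units; within the scatter) from compound 3 to compound 4, 1.1-fold (0.04 log units) apart, within the scatter of two such steps

Read the other way, adding butylcarbamoyl to the methyl compound gives a 25-fold higher number from compound 2 to compound 4 (1.40 log units; beyond the scatter), a large step that matches the one seen on the chloro side: the same change on two cores in this assay, a 28-fold higher number (1.44 log units; beyond the scatter) from compound 1 to compound 3 and a 25-fold higher number (1.40 log units; beyond the scatter) from compound 2 to compound 4, 1.1-fold (0.04 log units) apart, within the scatter of two such steps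

Within these four compounds, then, the two changes behave independently, with each step keeping its size whichever group stands at the other place; this does not show that the same would hold on a different core, since only two cores and one read-out in this assay are compared, and it does not explain why either step has the size it has.

From the compounds shown here alone, it remains open whether other groups in place of chloro, such as fluoro, methoxy or a carboxylic acid, would also leave the number where it is. Going by these compounds, it also remains open how the large step would change with a shorter chain such as ethyl, a longer chain such as octyl, or a plain acetyl group on that nitrogen in place of butylcarbamoyl.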